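Swapping the dichlorophenyl for fluorophenyl on the piperazine

The source may report more compounds than this note shows. Statements on the series, on what has been measured and on what is new or still open speak of the compounds shown alone.

Among the measured compounds shown here, compound 1 `COc1ccc(-c2cnc3nc(N)nc(N4CCN(C(=O)Nc5ccc(C)cc5)CC4)c3n2)cc1OC` gives 0.8 nM in a functional assay on cells (T-cell, Homo sapiens) for inhibition (on this read-out lower numbers stand for stronger inhibition and higher numbers for weaker inhibition), whereas compound 2 `COc1ccc(-c2cnc3nc(N)nc(N4CCN(c5cc(Cl)cc(Cl)c5)CC4)c3n2)cc1OC` gives 3400 nM in this assay, the higher of the two numbers measured so far; the only recorded step is a 4300-fold higher number from compound 1 to compound 2 (3.63 log units; beyond the scatter). Compound 3 `COc1ccc(-c2cnc3nc(N)nc(N4CCN(c5ccc(F)cc5)CC4)c3n2)cc1OC` differs from compound 2 by 4-fluorophenyl in place of 3,5-dichlorophenyl on an amine nitrogen in a ring. For the measured compounds named here, that single measured step replaces a carbamoyl group, not one aryl ring with another, so no measured step bears directly on this change. He therefore expects compound 3 to stay near compound 2, with a step of a 1.7-fold lower number from compound 2 to compound 3 (0.23 log units; within the scatter) in this assay. His estimate for compound 3 is 2000 nM, between 300 nM and 10000 nM.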

Compound 3, half-maximal inhibitory concentration: 100 nM
Estimate against measurement, compound 3: 20-fold (1.30 log units) above; measured number below the stated range.
By their numbers in this assay, from the lowest: compound 1; then compound 3; then compound 2.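

In this assay, exchanging one aryl group for another on this amine nitrogen proves a large change in its own right: 4-fluorophenyl in place of 3,5-dichlorophenyl gives a 34-fold lower number from compound 2 to compound 3 (1.53 log units; beyond the scatter) at this position. The carbamoyl group is therefore not the only thing that matters here, although a 130-fold higher number from compound 1 to compound 3 (2.10 log units; beyond the scatter) still separates the 4-fluorophenyl compound from the urea. Nothing available accounts for either step.

The compounds shown leave open whether the difference follows the fluorine or the two chlorines, which plain phenyl or 4-chlorophenyl on the same nitrogen would help separate. They also leave open how an acetyl or benzoyl group there would compare with (4-methylphenyl)carbamoyl.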